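Ring opening of the acid side chain in two cores

This account rests on a few compounds, and the source may have more. Where it says the series, first, only, none or still open, it means among the compounds named here.

The set holds two cores. Compound 1 `O=C(O)C1CC1c1ccc(NCc2cccc(Oc3ccccc3)c2)cc1` and compound 2 `O=C(O)CCCc1ccc(NCc2cccc(Oc3ccccc3)c2)cc1` share one core; compound 3 `O=C(O)C1CC1c1ccc(NCc2ccc(-c3ccccc3)cc2)cc1` and compound 4 `O=C(O)CCCc1ccc(NCc2ccc(-c3ccccc3)cc2)cc1` share the other. How the two cores differ is not broken down here. In a functional assay on CHO cells for agonist activity at Free fatty acid receptor 1 (Homo sapiens), read by reporter gene assay (a higher number here means a larger maximal response, a lower number a smaller maximal response), compound 1 gives 74% and compound 2 gives 74%; in the same assay compound 3 gives 80%, while compound 4 is not yet measured.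

The change within the first core is 3-carboxypropyl in place of 2-carboxycyclopropyl on an aromatic carbon. It made the step of no change at the digits printed from compound 1 to compound 2 (within the scatter). The change from compound 3 to compound 4 is the same: 3-carboxypropyl in place of 2-carboxycyclopropyl on an aromatic carbon. The place it sits is described in the same words for both pairs.

Going by the values given here, for compound 4 a step of no change at the digits printed from compound 3 to compound 4 (within the scatter) is expected, because the one earlier instance of this change, no change at the digits printed from compound 1 to compound 2 (within the scatter), stayed within the scatter. This expectation rests on a single measured pair in this assay, so the range is kept wide.

Compound 4 is estimated to give about 80%, expected between 68% and 92%.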

Compound 4, largest response reached (reported as percent of maximum), in percent of the reference or control that the assay uses: 62%
Compound 4: the middle estimate sits 18 percentage points above what was measured; measured number outside the range, below it.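

In this assay, 3-carboxypropyl in place of 2-carboxycyclopropyl on an aromatic carbon gives a number 18 percentage points lower from compound 3 to compound 4 (beyond the scatter). The same change therefore does not carry over with the same result from one core to the other in this series: the same change on two cores in this assay, no change at the digits printed (within the scatter) from compound 1 to compound 2 and a number 18 percentage points lower (beyond the scatter) from compound 3 to compound 4, 18 percentage points apart, beyond the scatter of two such steps

This shows that, across these two pairs, the effect of opening the ring on the largest response depends on the core it sits on. It does not show which feature of the two cores accounts for the gap, and two pairs give no rule for predicting the step on a third core.

The compounds shown leave open whether a shorter chain such as 2-carboxyethyl would follow the 3-carboxypropyl result on either core. They also leave open whether a tetrazole in place of the carboxylic acid would keep the gap between the two cores.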